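The source may report more compounds than this note shows. Statements on the series, on what has been measured and on what is new or still open speak of the compounds shown alone.

Measured so far:
- compound 1, `CCc1cccc(NC(=O)N[C@H](C)c2ccccc2)c1`, 71%
- compound 2, `CCc1ccc(NC(=O)N[C@H](C)c2ccccc2)cc1`, 47%
- compound 3, `CCc1ccc(NC(=O)N[C@@H](C)c2ccccc2)cc1`, 95%

Three ureas have been run through an ADME assay on the whole organism with Oryza sativa as the target, tested at 1 uM; on this read-out higher numbers stand for a weaker effect at the one concentration tested and lower numbers for a stronger effect. Compound 1, `CCc1cccc(NC(=O)N[C@H](C)c2ccccc2)c1`, gives 71%. Compound 2, `CCc1ccc(NC(=O)N[C@H](C)c2ccccc2)cc1`, gives 47%, and compound 3, `CCc1ccc(NC(=O)N[C@@H](C)c2ccccc2)cc1`, gives 95%. Compound 3 therefore stands highest of the three in this assay, beyond the scatter of both others. Going by the values given here, the only single-point step among the measured compounds is a number 48 percentage points higher from compound 2 to compound 3 (beyond the scatter), which rests on (the fact that compounds 2 and 3 differ only in the configuration as drawn).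

Compound 4, `C[C@H](NC(=O)Nc1ccc(I)cc1)c1ccccc1`, is not yet measured. It differs from compound 3 by iodo in place of ethyl on an aromatic carbon. Among the compounds with values here, no measured step touches this kind of change: the one step on record concerns configuration only, and the comparison of compound 1 with compound 2 concerns where the ethyl sits, not what replaces it. There is thus no measured basis for the direction of the step, and compound 3 already sits near the top of the scale in this assay. The expected step is a number 15 percentage points lower from compound 3 to compound 4 (beyond the scatter), drawn wide. Compound 4 is estimated at 80%, within a range from 45% to 100%.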

Compound 4, a percentage reported as activity, at one concentration (the size of the read-out at that concentration, not a potency): 97%
For compound 4 the middle estimate is 17 percentage points below the measured one, and the stated range covers the measured number.
By their numbers in this assay, from the lowest: compound 2; then compound 1; then compounds 3 and 4 (each within the scatter of the next).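

In this assay, putting iodo in place of ethyl on an aromatic carbon, para to a large group, gives a number 2 percentage points higher from compound 3 to compound 4 (within the scatter) and so does not separate the two groups at this position in this configuration. Going by these compounds alone, the earlier compounds spoke only to where the ethyl sits and how the stereocentre is drawn, whereas this pair is the first to speak to what the group itself may be. Compound 3 and compound 4 both lie at the weak end of the values shown, so the exchange brings no stronger effect here, though this pair alone says nothing about other groups at this position, and nothing at hand explains the lack of a difference.

Within the data shown here, it remains open whether iodo would behave the same way in the opposite configuration, the one drawn in compound 2, which gives 47% with ethyl. Also open, from the compounds shown here alone, is how the read-out would respond at this aromatic carbon to a fluoro group, a methoxy group, an amine or a carboxylic acid, or to a longer chain in place of ethyl.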